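Compound 2 to Compound 3: One Group Changed, One Number Expected

The source may report more compounds than this note shows. Statements on the series, on what has been measured and on what is new or still open speak of the compounds shown alone.

Measured compounds:
- Compound 1 `COc1ccc(-c2cc(=O)c3cc(C(=O)O)ccc3o2)cc1` gives 13% in a functional assay on the whole organism (stomach) for inhibition, with Rattus norvegicus as the target, at a dose of 80 mg/kg; a lower number here means less inhibition, a higher number more inhibition at the dose given (going by the name of the read-out).
- Compound 2 `CC(C)Oc1c(-c2ccc(C(C)C)cc2)oc2ccc(C(=O)O)cc2c1=O` gives 20% in this assay.

Compound 2 holds the higher of the two numbers measured in this assay, yet its nearest neighbour, compound 1, lies only a little lower, and that gap is within the scatter of the method, so the inhibition of the two compounds in this assay is level. Both numbers are modest.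

Compound 3 `COc1ccc(-c2oc3ccc(C(=O)O)cc3c(=O)c2OC(C)C)cc1` has not been measured. It differs from compound 2 in one place: methoxy in place of isopropyl on an aromatic carbon. Within the data shown here, no step between measured compounds shows what this exchange does, so the step from compound 2 to compound 3 in this assay is expected to be small, with no clear direction beyond the scatter: a number 3 percentage points lower from compound 2 to compound 3 (within the scatter). Resting on compound 2 at 20% and compound 1 at 13%, compound 3 is estimated to give 17%, within a range of 5% to 32%.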

Compound 3, a percentage reported as inhibition, in the whole organism at one dose (the size of the read-out at that dose, not a potency): 35%
Compound 3: the middle estimate sits 18 percentage points below what was measured; the measured number lies above the stated range.
By their numbers in this assay, from the lowest: compounds 1 and 2 (each within the scatter of the next); then compound 3.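

In this assay the exchange of 4-isopropylphenyl for 4-methoxyphenyl gives a number 15 percentage points higher from compound 2 to compound 3 (beyond the scatter) and so shows that this place on the aromatic ring, para to a large group, does bear on the read-out. With the methoxy kept, isopropoxy in place of hydrogen on an aromatic carbon gives a number 22 percentage points higher from compound 1 to compound 3 (beyond the scatter) as a second single change, which the earlier pair could not show, since compound 1 and compound 2 differ in more than one place. Nothing given here accounts for either step.

The compounds shown leave open whether other groups at the para place on the ring, such as a hydroxyl, a fluorine or an amine, would match the methoxy. They also leave open whether a longer chain in place of the isopropoxy would carry the number further.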